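Methoxy to Hydroxy on a Pyrazinyl Triazole Thione Hydrazone

This account rests on a few compounds, and the source may have more. Where it says the series, first, only, none or still open, it means among the compounds named here.

Measured compounds:
compound 1, `COc1cc(OC)c(OC)cc1/C=N/n1c(S)nnc1-c1cnccn1`, 143000 nM
compound 2, `COc1ccccc1/C=N/n1c(S)nnc1-c1cnccn1`, 173000 nM

Of the compounds shown here, two have been tested in an ADME assay on NIH3T3 cells (Mus musculus) for cytotoxicity, read by MTT assay, with a stated time of 24 h; on this read-out higher numbers stand for weaker inhibition and lower numbers for stronger inhibition. Compound 2 stands highest of the two numbers, with compound 1 the nearest, a difference that lies within the scatter of repeated measurements. On these two values, then, neither compound can be called weaker or stronger than the other; both sit at the weak end of the read-out.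

Compound 3, `Oc1ccccc1/C=N/n1c(S)nnc1-c1cnccn1`, has not yet been measured. It differs from compound 2 in one place:

hydrogen in place of methyl on an oxygen on an aromatic ring

For the measured compounds named here, no step between two measured compounds is available to guide the size of this change. Going by the values given here, with only two values to go on, the expected step of a 1.1-fold lower number from compound 2 to compound 3 (0.03 log units; within the scatter) is none beyond the scatter. Compound 3 is therefore expected to give an estimated 160000 nM, with a range from 70000 nM to 350000 nM.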

Compound 3, half-maximal inhibitory concentration: 131000 nM
Compound 3: middle estimate off by 1.2-fold (0.09 log units), on the high side; the measured number falls inside the stated range.
By their numbers in this assay, from the lowest: compounds 3, 1 and 2 (each within the scatter of the next).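

In this assay, for the compounds shown here, the methoxy to hydroxy change gives a 1.3-fold lower number from compound 2 to compound 3 (0.12 log units; within the scatter) and is the first single-place step that can be read on this core. It shows that compound 2 and compound 3 cannot be told apart in this assay, whether the oxygen on the aromatic ring carries a methyl or a hydrogen. No available evidence bears on this result, so nothing can be said about what lies behind it.

The compounds shown leave open whether a longer chain such as ethyl on the same oxygen, or an amine or a carboxylic acid in place of the methoxy, would read differently. They also leave open whether the same change would read alike on the core of compound 1, which carries further methoxy groups.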